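Methyl for methoxy on compound 3

The source may report more compounds than this note shows. Statements on the series, on what has been measured and on what is new or still open speak of the compounds shown alone.

In a functional assay on HeLa cells (Homo sapiens) for antiproliferative activity, read by MTT assay, with a stated time of 48 h (a lower number here means a stronger inhibitor, a higher number a weaker inhibitor), compound 3 (`COc1ccc2[nH]c(-c3cn(-c4ccccc4)nc3-c3ccc(F)cc3)nc2c1`) gives 7510 nM and compound 1 (`Cc1ccc2[nH]c(-c3cn(-c4ccccc4)nc3-c3ccccc3)nc2c1`) gives 6560 nM so these two lie within the scatter of each other and together mark the high end of the numbers. Compound 2 (`Fc1ccc(-c2nn(-c3ccccc3)cc2-c2nc3cc(Cl)ccc3[nH]2)cc1`) stands apart at 2770 nM with a lower number than either, which means a stronger inhibitor.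

The next change puts methyl in place of methoxy on an aromatic carbon of the core, giving compound 4 (`Cc1ccc2[nH]c(-c3cn(-c4ccccc4)nc3-c3ccc(F)cc3)nc2c1`) with this difference (methyl in place of methoxy on an aromatic carbon). Among the measured compounds shown here, the one measured step at this place is a 2.7-fold higher number from compound 2 to compound 3 (0.43 log units; beyond the scatter) on putting methoxy in place of chloro, a modest change beyond the scatter. It shows that this place can shift the number, but it says nothing direct about methyl. Compound 1 also carries a methyl and gives 6560 nM despite differing elsewhere, which points to little change. The expected result is a 1.2-fold lower number from compound 3 to compound 4 (0.06 log units; within the scatter) and this estimated step stays within the scatter. Compound 4 is estimated at 6500 nM (expected range 3500 nM to 12000 nM).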

Compound 4, half-maximal inhibitory concentration: 3630 nM
For compound 4 the middle estimate is 1.8-fold (0.25 log units) above the measured one; the measured number falls inside the stated range.
By their numbers in this assay, from the lowest: compounds 2, 4, 1 and 3 (each within the scatter of the next, the first and the last beyond it).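

At this place on the core, this assay tells methyl from methoxy: the swap gives a 2.1-fold lower number from compound 3 to compound 4 (0.32 log units; beyond the scatter) and so, among the three groups seen here, methoxy alone stands apart from the other two. Methyl and chloro cannot be told apart, with a 1.3-fold higher number from compound 2 to compound 4 (0.12 log units; within the scatter) as the step between them, and with methyl held in place, putting fluoro in place of hydrogen on an aromatic carbon elsewhere gives a 1.8-fold lower number from compound 1 to compound 4 (0.26 log units; within the scatter) and likewise no clear shift. Nothing measured here gives a reason for the methoxy result.

The compounds shown carry only methyl, chloro and methoxy at this place, so how an amine, a carboxylic acid or a longer chain such as propyl would behave there stays open. From the compounds shown here alone, whether the fluoro step looks the same with chloro or methoxy at this place is also open.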